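Chain shortening on the alkyne arm of compound 1

A few compounds are considered here, and "the series" means these few. Any claim that something is new, unique, unknown or untested is made for them only; others in the source may bear on it.

Among the measured compounds shown here, compound 1 `CCCCCC#Cc1cn(C/C=C/CN2C(=O)c3ccccc3C2=O)c(=O)[nH]c1=O` is the single compound of the pair with a number in a functional assay on HeLa cells (Homo sapiens) for antiproliferative activity, read by MTT assay, with a stated time of 3 days; on this read-out lower numbers stand for stronger inhibition and higher numbers for weaker inhibition: compound 1 gives 91000 nM. Compound 2 `O=C1c2ccccc2C(=O)N1C/C=C\Cn1cc(C#CCCc2ccccc2)c(=O)[nH]c1=O` is reported in this assay only as a limit, > 100000 nM, and not as a number, so within the shown data compound 1 stands as the only measured point, with the limit of > 100000 nM in this assay, at which 1 of the 2 values shown sits, beside it. Compound 3 `CCCCC#Cc1cn(C/C=C/CN2C(=O)c3ccccc3C2=O)c(=O)[nH]c1=O` differs from compound 1 by hydrogen in place of methyl on a saturated chain carbon, four bonds along the chain from a triple-bonded carbon; read one bond further out, the change is butyl to propyl on the same saturated chain. For the measured compounds named here, no step between two measured compounds is available for this kind of change, so the expected step in this assay is small, none beyond the scatter or at most a slight move toward weaker inhibition. On that basis compound 3 is estimated at 110000 nM, within 45000 nM to 270000 nM, which means an expected step from compound 1 to compound 3 of a 1.2-fold higher number from compound 1 to compound 3 (0.08 log units; within the scatter).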

Compound 3, half-maximal inhibitory concentration: 89000 nM
For compound 3 the middle estimate is 1.2-fold (0.09 log units) above the measured one, and the stated range covers the measured number.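

Hydrogen in place of methyl on the saturated chain, read also as butyl to propyl, gives the first readable step in the series in this assay: a 1.0-fold lower number from compound 1 to compound 3 (0.01 log units; within the scatter). At this position, this shortening of the chain therefore leaves the read-out within the scatter, and a second compound joins compound 1 with a number rather than a limit. Compound 2 stands in the series only as a limit and not as a number, so no step to it can be read: the limit of > 100000 nM in this assay, at which 1 of the 3 values shown sits.

Going by these compounds, a single step within the scatter says little about the wider reach of this position, and a much shorter ethyl arm or a longer chain remains open. On these data alone, an amine or a carboxylic acid on the same saturated chain also remains open, as does any change to the rest of the shared core.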